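Aminothiophene amides: chloro to nitro on one aryl ring

The source may hold more compounds than are shown below. What is called first, only, known or untested is meant among the compounds shown, and "the series" means these compounds.

Compound 1 `COC(=O)c1c(N)sc(-c2ccc(Cl)cc2)c1-c1ccc(Cl)cc1` — 5040 nM
Compound 2 `Nc1sc(-c2ccc(Cl)cc2)c(-c2ccc(Cl)cc2)c1C(=O)NC1CC1` — 1950 nM
Compound 3 `Nc1sc(-c2ccc(Cl)cc2)c(-c2ccc(Cl)cc2)c1C(=O)N1CCCC1` — 890 nM

All three share one core and differ only in the group on the carbonyl carbon. In a functional assay on A549 cells (Homo sapiens) for cytotoxicity, read by sulforhodamine B assay, with a stated time of 72 h (a lower number here means a stronger inhibitor, a higher number a weaker inhibitor), compound 3 gives the lowest of the three numbers: the nearest is compound 2, with a 2.2-fold lower number from compound 2 to compound 3 (0.34 log units; beyond the scatter), the furthest compound 1, with a 5.7-fold lower number from compound 1 to compound 3 (0.75 log units; beyond the scatter); between the other two lies a 2.6-fold lower number from compound 1 to compound 2 (0.41 log units; beyond the scatter). Compound 4 `Nc1sc(-c2ccc([N+](=O)[O-])cc2)c(-c2ccc(Cl)cc2)c1C(=O)N1CCCC1` differs from compound 3 in one place: nitro in place of chloro on an aromatic carbon. For the measured compounds named here, none of the measured steps touches either aryl ring; each of them concerns the group on the carbonyl carbon, so they give no direct guide to this change, and the data hold nothing on what nitro in place of chloro does here. The account therefore expects no step beyond the scatter from compound 3 to compound 4, a 1.2-fold higher number from compound 3 to compound 4 (0.09 log units; within the scatter), with a wide uncertainty. Compound 4 is estimated at 1100 nM in this assay, with a range from 300 nM to 4000 nM.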

Compound 4, half-maximal inhibitory concentration: 10700 nM
For compound 4 the middle estimate is 9.7-fold (0.99 log units) below the measured one; the whole stated range lies below it.
By their numbers in this assay, from the lowest: compound 3; then compound 2; then compound 1; then compound 4.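

In this assay, for the compounds shown here, the 4-chlorophenyl to 4-nitrophenyl change is the first to touch an aryl ring, and it moves the number the other way (a 12-fold higher number from compound 3 to compound 4 (1.08 log units; beyond the scatter)). This step is larger than the widest one seen on the carbonyl carbon (a 5.7-fold lower number from compound 1 to compound 3 (0.75 log units; beyond the scatter)), so what sits on this aromatic carbon, para to a large group, counts for at least as much here as the group on the carbonyl carbon. Nothing shown bears on the cause of this step.

As far as these compounds go, it remains open whether an amino group or a fluoro group in this place would stay close to compound 3 or fall nearer to compound 4. Also open, from the compounds shown here alone, is whether nitro in place of chloro on the other aryl ring, or with cyclopropylamino on the carbonyl carbon, would give a step of similar size.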